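The source may report more compounds than this note shows. Statements on the series, on what has been measured and on what is new or still open speak of the compounds shown alone.

Measured in an ADME assay on liver (Homo sapiens) for metabolic stability, read by LC-MS, using microsomes and NADPH; on this read-out higher numbers stand for a more stable compound and lower numbers for a less stable compound:
compound 1 `CCCN(Cc1ccc(OCCN2C(=O)CCC2=O)c(C)c1)C(CC(=O)O)c1ccc(Cl)cc1`: 85%
compound 2 `CCCN(Cc1ccc(OCCn2c(=O)ccn(C)c2=O)c(C)c1)C(CC(=O)O)c1ccc(Cl)cc1`: 30%
compound 3 `Cc1cc(CN(C2CCC2)C(CC(=O)O)c2ccc(Cl)cc2)ccc1OCCn1c(=O)ccn(C)c1=O`: 20%

Compound 2 stands level with compound 3 and well under compound 1, as two steps show: a number 10 percentage points lower from compound 2 to compound 3 (within the scatter), and a number 55 percentage points lower from compound 1 to compound 2 (beyond the scatter). Compound 4 `CCCN(Cc1ccc(OCCn2c(=O)ccn(C)c2=O)c(OC)c1)C(CC(=O)O)c1ccc(Cl)cc1` carries methoxy in place of methyl on an aromatic carbon, methoxy in place of methyl on an aromatic carbon. Neither measured step touches that carbon. The large one lies in the group on the saturated chain and the small one on the amine nitrogen, so the data give no direct size for this change. No shift beyond the scatter is expected in this assay, with the expected change being a number 5 percentage points lower from compound 2 to compound 4 (within the scatter). Compound 4 is estimated at 25%, with an expected range of 10% to 45%.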

Compound 4, percent of the compound remaining: 61%
Compound 4: the middle estimate sits 36 percentage points below what was measured; measured number above the stated range.
By their numbers in this assay, from the lowest: compounds 3 and 2 (each within the scatter of the next); then compound 4; then compound 1.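

In this assay, going by these compounds alone, the aromatic carbon carrying methyl in the earlier compounds proves responsive: methoxy in place of methyl gives a number 31 percentage points higher from compound 2 to compound 4 (beyond the scatter) on an otherwise unchanged structure. Within the data shown here, the earlier steps touched only the group on the saturated chain and the group on the amine nitrogen, so this is the first sign that this carbon alone can move the read-out. Nothing available bears on the reason for this step. Open, as far as these compounds go, is whether ethoxy or a fluorine atom on this carbon gives a step of similar size. Also open, from the compounds shown here alone, is whether methoxy gives the same step with cyclobutyl on the amine nitrogen, as in compound 3.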